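The source may report more compounds than this note shows. Statements on the series, on what has been measured and on what is new or still open speak of the compounds shown alone.

In a physicochemical assay for lipophilicity (a lower number here means a more polar compound, a higher number a more lipophilic compound), compound 2 `CN1CCN(CCCS(=O)(=O)c2ccc3nc(NC(=O)NC(=O)c4ccccc4Cl)sc3c2)CC1` gives 1.8; compound 1 `CN1CCN(CCCS(=O)(=O)c2ccc3nc(NC(=O)NC(=O)c4cccc(-n5cccn5)c4Cl)sc3c2)CC1` gives 1.6 in this assay, within the scatter of compound 2, while compound 3 `CN1CCCN(CCCS(=O)(=O)c2ccc3nc(NC(=O)NC(=O)c4ccccc4Cl)sc3c2)CC1` gives 1, beyond it. The change a number 0.20 log units higher from compound 1 to compound 2 (within the scatter) removed a pyrazolyl group from the chlorinated ring, and a number 0.80 log units lower from compound 2 to compound 3 (beyond the scatter) altered the basic ring at the other end. Compound 4 `Cc1cc(C)n(-c2ccc(Cl)c(C(=O)NC(=O)Nc3nc4ccc(S(=O)(=O)CCCN5CCN(C)CC5)cc4s3)c2)n1` differs from compound 2 by 3,5-dimethyl-1H-pyrazol-1-yl in place of hydrogen on an aromatic carbon, on a carbon meta to a large group and para to a chloro group. The step from compound 1 to compound 2 is the one that bears on this change, and it lay within the scatter. A step of a number 0.20 log units higher from compound 2 to compound 4 (within the scatter) is therefore expected for compound 4, not beyond the scatter. Compound 4 is estimated at 2, between 1.5 and 2.5.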

Compound 4, distribution coefficient: 2.5
The estimate for compound 4 lay 0.50 log units below the measured number; the measured number falls inside the stated range.
By their numbers in this assay, from the lowest: compound 3; then compounds 1 and 2 (each within the scatter of the next); then compound 4.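

In this assay, 3,5-dimethyl-1H-pyrazol-1-yl in place of hydrogen on the carbon para to a chloro group gave a number 0.70 log units higher from compound 2 to compound 4 (beyond the scatter) and so showed that this position can respond clearly to such a group. The earlier step, a number 0.20 log units higher from compound 1 to compound 2 (within the scatter), involved an unmethylated pyrazolyl on a different carbon of the ring and does not carry over to this position.

As far as these compounds go, a plain 1H-pyrazol-1-yl on this same carbon would separate the part played by the two methyl groups from that of the position, and that question stays open. Nothing measured here explains the size of the new step.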